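Swapping Fluoro for Nitro on the Aryl Ring

The source may hold more compounds than are shown below. What is called first, only, known or untested is meant among the compounds shown, and "the series" means these compounds.

Compound 1 `COc1ccc(C2=Cc3ccc(F)cc3C(CC(=O)C(C)O)N2c2ccc(C)cc2)cc1`: 12700 nM
Compound 2 `COc1ccc(C2=Cc3ccc(F)cc3C(CC(=O)C(C)O)N2c2ccc(Cl)cc2)cc1`: 9900 nM
Compound 3 `COc1ccc(C2=Cc3ccc(F)cc3C(CC(=O)C(C)O)N2c2ccc(F)cc2)cc1`: 14000 nM

Three compounds sharing one core were tested in an ADME assay on TZM cells (Homo sapiens) for cytotoxicity, read by CellTiter-Glo, with a stated time of 48 h; a higher number here means that more compound is tolerated, a lower number that less compound is tolerated. They differ only in the group on one aromatic carbon of the phenyl ring bound to the ring nitrogen: methyl in compound 1, chloro in compound 2, fluoro in compound 3. Compound 3 cannot be set apart from the other two, since a 1.1-fold higher number from compound 1 to compound 3 (0.04 log units; within the scatter) and a 1.4-fold higher number from compound 2 to compound 3 (0.15 log units; within the scatter) both lie within the scatter, as does a 1.3-fold lower number from compound 1 to compound 2 (0.11 log units; within the scatter).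

Compound 4 `COc1ccc(C2=Cc3ccc(F)cc3C(CC(=O)C(C)O)N2c2ccc([N+](=O)[O-])cc2)cc1` introduces a group not yet seen in this series: nitro in place of fluoro on an aromatic carbon, placed para to a large group. For the measured compounds named here, no measured step involves a nitro, so the only guide is that three quite different groups at this position gave numbers within the scatter of each other. On that basis the step of a 1.2-fold lower number from compound 3 to compound 4 (0.07 log units; within the scatter) is expected to stay within the scatter, with no clear direction. Compound 4 is therefore estimated at 12000 nM in this assay, within a range of 6000 nM to 25000 nM.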

Compound 4, half-maximal cytotoxic concentration: 10100 nM
Beside the measured number, compound 4's estimate is 1.2-fold (0.07 log units) above it; measured number inside the range.
By their numbers in this assay, from the lowest: compounds 2, 4, 1 and 3 (each within the scatter of the next).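

Nitro brings three heavy atoms and two hydrogen-bond acceptors where fluoro brought one heavy atom and none, yet in this assay this larger change gives a 1.4-fold lower number from compound 3 to compound 4 (0.14 log units; within the scatter) and the other two swaps give a 1.0-fold higher number from compound 2 to compound 4 (0.01 log units; within the scatter) and a 1.3-fold lower number from compound 1 to compound 4 (0.10 log units; within the scatter) without leaving the scatter. This aromatic carbon has therefore now carried a group with hydrogen-bond acceptors as well as methyl, chloro and fluoro, and the four compounds still cannot be set apart in tolerated concentration. No measurement offered here gives a reason for this sameness.

The compounds shown leave open whether an amine or a carboxylic acid on this same carbon would also stay within the scatter. They also leave open how far a change elsewhere on the shared core would move the number.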